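Moving the carboxy group and dropping the chlorine

A few compounds are considered here, and "the series" means these few. Any claim that something is new, unique, unknown or untested is made for them only; others in the source may bear on it.

Measured so far:
- Compound 1 `COc1cc(C(=O)O)ccc1OCCCCOc1ccc(C(=O)CC(C)(C)C)c(O)c1C`: 109%
- Compound 2 `Cc1c(OCCCCOc2ccc(C(=O)O)c(Cl)c2)ccc(C(=O)CC(C)C)c1O`: 49.5%

The read-out here is an assay on HEK293 cells for positive allosteric modulation of metabotropic glutamate receptor 3 (Rattus norvegicus), read by thallium flux, with a stated time of 2.5 min; on this read-out higher numbers stand for larger maximal responses and lower numbers for smaller maximal responses. In this assay compound 1 reaches 109%, while compound 2 reaches only 49.5%, so compound 2 stands lowest of the two, and the gap to compound 1 is far beyond the usual scatter. No single-change comparison between the two measured compounds exists, because they differ in more than one place, so nothing is known about how any one change shifts the maximal response.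

Compound 3 `Cc1c(OCCCCOc2cccc(C(=O)O)c2)ccc(C(=O)CC(C)C)c1O` is not yet measured. It differs from compound 2 as follows: 3-carboxyphenyl in place of 4-carboxy-3-chlorophenyl on an oxygen on a saturated carbon.

Within the data shown here, with no directly comparable step in hand, the expectation for this assay rests on the two numbers alone. Compound 3 is expected to lie above compound 2, since compound 2 sits at the low end of what has been seen, and the step from compound 2 to compound 3 is estimated at a number 15.5 percentage points higher from compound 2 to compound 3 (beyond the scatter). For compound 3 the maximal response is therefore estimated at 65%, in a range from 30% to 105%.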

Compound 3, largest response reached (reported as percent of maximum), in percent of the reference or control that the assay uses: 69.9%
For compound 3 the middle estimate is 4.9 percentage points below the measured one, and the stated range covers the measured number.
By their numbers in this assay, from the lowest: compound 2; then compound 3; then compound 1.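

In this assay, putting 3-carboxyphenyl in place of 4-carboxy-3-chlorophenyl on an oxygen on a saturated carbon gives a number 20.4 percentage points higher from compound 2 to compound 3 (beyond the scatter). Among these compounds, this is the first comparison here in which only one place changes, and it shows that the group at this position can by itself shift the maximal response beyond the usual scatter, with the rest of the molecule held the same. Nothing measured here explains why the response rises with this change.

The swap bundles two differences, since the chlorine is gone and the carboxy group sits at a different place on the ring, so this single step cannot say how much each one contributes. It also leaves open whether the carboxylic acid itself is needed at this position, or whether another group such as an amide or a tetrazole could stand in its place and still give a comparable maximal response.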